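This account rests on a few compounds, and the source may have more. Where it says the series, first, only, none or still open, it means among the compounds named here.

In a functional assay on NCI-H522 cells (Homo sapiens) for inhibition, read by sulforhodamine B assay, with a stated time of 48 h (a higher number here means a weaker inhibitor of growth, a lower number a stronger inhibitor of growth), compound 1 `CCCCCCCCCCCC[C@@H](O)[C@H]1CC[C@H]([C@H](O)CCCCCCCCCCNC(=O)c2ccnn2C)O1` gives 1410 nM and compound 2 `CCCCCCCCCCCC[C@@H](O)[C@H]1CC[C@H]([C@H](O)CCCCCCCCCCN(C)C(=O)c2ccnn2C)O1` gives 2290 nM. Compound 2 therefore stands within the scatter of compound 1, and the two cannot be ranked. Compound 3 `CCCCCCCCCCCC[C@@H](O)[C@H]1CC[C@H]([C@H](O)CCCCCCCCCCNCc2ccnn2C)O1` differs from compound 2 on the same saturated chain carbon: ((1-methyl-1H-pyrazol-5-yl)methyl)amino in place of methyl((1-methyl-1H-pyrazol-5-yl)carbonyl)amino on a saturated chain carbon, ten or more bonds along the chain from an oxygen on a saturated carbon and a saturated ring carbon. Here ((1-methyl-1H-pyrazol-5-yl)methyl)amino takes the place of methyl((1-methyl-1H-pyrazol-5-yl)carbonyl)amino. Going by the values given here, only one measured step bears on this change, a 1.6-fold higher number from compound 1 to compound 2 (0.21 log units; within the scatter), and it covers only the methyl on the amide-type nitrogen. Among the compounds with values here, no measured pair shows what happens when the carbonyl is lost, so the direction remains open and the range must stay wide. On this limited evidence, no step beyond the scatter is expected in this assay. The estimated step is a 1.4-fold lower number from compound 2 to compound 3 (0.16 log units; within the scatter). For compound 3 the estimated value is 1600 nM, with an expected range of 500 nM to 5000 nM.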

Compound 3, concentration for 50% growth inhibition: 1290 nM
Compound 3: the middle estimate sits 1.2-fold (0.09 log units) above what was measured, within the range that was stated.
By their numbers in this assay, from the lowest: compounds 3, 1 and 2 (each within the scatter of the next).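

In this assay, (1-methyl-1H-pyrazol-5-yl)methyl in place of (1-methyl-1H-pyrazol-5-yl)carbonyl on an amine nitrogen gives a 1.1-fold lower number from compound 1 to compound 3 (0.04 log units; within the scatter), and the fuller change, which also removes the methyl on that nitrogen, gives a 1.8-fold lower number from compound 2 to compound 3 (0.25 log units; within the scatter). The carbonyl, which the earlier pair left untouched, can therefore be absent at this far end of the chain without a step beyond the scatter, and the three compounds cannot be ranked. Nothing measured here offers an explanation for this result.

As far as these compounds go, all three compounds carry the 1-methyl-1H-pyrazol-5-yl ring, so it remains open whether a phenyl or pyridine ring would serve in its place. Also open, from the compounds shown here alone, are a sulfonamide at this nitrogen, the amine with a methyl on its nitrogen, and a shorter chain leading to it.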